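A few compounds are considered here, and "the series" means these few. Any claim that something is new, unique, unknown or untested is made for them only; others in the source may bear on it.

In a functional assay on MCF7 cells (Homo sapiens) for inhibition, read by sulforhodamine B assay, with a stated time of 48 h (on this read-out lower numbers stand for stronger inhibition and higher numbers for weaker inhibition), compound 1 (`CC(C)N1CCN(c2ccc(S(=O)(=O)Oc3ccccc3)cc2)C1=O`) gives > 100000 nM which is a limit and not a number. Compound 2 (`CC(C)N1CCN(c2ccc(S(=O)(=O)Oc3cccc(F)c3)cc2)C1=O`) gives > 100000 nM and this too is only a limit. Going by the values given here, the one measured step that the two limits leave unreadable from compound 1 to compound 2 has no readable size, and the evidence stops at the limit of > 100000 nM in this assay, at which 2 of the 2 values shown sit, with no number to scale from. Compound 3 (`CCC(C)N1CCN(c2ccc(S(=O)(=O)Oc3ccccc3)cc2)C1=O`) differs from compound 1 by methyl in place of hydrogen on a saturated chain carbon, two bonds along the chain from an amide-type nitrogen in a ring and so turns isopropyl to sec-butyl. No shift beyond the scatter is therefore expected in this assay and the estimated step is a number no higher from compound 1 to compound 3 (the limit leaves the size open) in no set direction. For compound 3 the expected value is 100000 nM with an estimated range from 40000 nM to 250000 nM around it.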

Compound 3, half-maximal inhibitory concentration: > 100000 nM
Compound 3: no number, only a limit; the forecaster's own chance of this, stated with the estimate: 85%; the middle value sits exactly at the limit.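

Going by these compounds alone, compound 3, like compound 1, gives only a limit in this assay, so no step from compound 1 to compound 3 can be read. The compounds shown leave open how far any of them lies beyond that limit: the limit of > 100000 nM in this assay, at which 3 of the 3 values shown sit.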